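The source may report more compounds than this note shows. Statements on the series, on what has been measured and on what is new or still open speak of the compounds shown alone.

Working notes on the sulfonanilide series. Within the data shown here, compound 1 `O=S(=O)(Nc1ccccc1)c1ccccc1` is the unsubstituted parent; in an ADME assay, compound 1 gives 9.1, the highest of the two numbers so far. Among the measured compounds shown here, the one measured neighbour is compound 2 `O=[N+]([O-])c1cccc(NS(=O)(=O)c2ccccc2)c1`, which in this assay gives 7.93. For the measured compounds named here, the single step between them, nitro in place of hydrogen on an aromatic carbon, gives a number 1.17 log units lower from compound 1 to compound 2 (beyond the scatter).

Compound 3 `O=S(=O)(Nc1ccc(F)cc1)c1ccccc1` is not yet measured. Relative to compound 1 the change is fluoro in place of hydrogen on an aromatic carbon. Going by the values given here, the only step that bears on it is the nitro step, which was large; a fluoro entering on the same ring is a different and smaller change, and no measured step shows its size here. The step of a number 0.20 log units lower from compound 1 to compound 3 (within the scatter) is therefore expected to be small, in the downward direction if anything, and may not exceed the scatter. For compound 3 the estimate in this assay is 8.9, expected to lie between 8.6 and 9.2.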

Compound 3, acid dissociation constant: 8.85
Compound 3: middle estimate off by 0.05 log units, on the high side, and the stated range covers the measured number.
By their numbers in this assay, from the lowest: compound 2; then compounds 3 and 1 (each within the scatter of the next).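

In this assay, fluoro in place of hydrogen on an aromatic carbon, para to a large group, gives a number 0.25 log units lower from compound 1 to compound 3 (within the scatter), so compound 3 and compound 1 cannot be told apart at this position. Compound 2 showed only that one substitution on this ring can carry the number beyond the scatter; compound 3 adds that another, fluoro, does not do so here. Nothing at hand gives a reason for the size of this step.

The compounds shown leave open whether nitro on this same carbon would give a step like the one seen for compound 2, since compound 2 and compound 3 differ in both group and place. They also leave open what a nitrile, a trifluoromethyl group or an amine on this carbon would give in this assay.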